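The source may report more compounds than this note shows. Statements on the series, on what has been measured and on what is new or still open speak of the compounds shown alone.

Measured compounds:
compound 1 `COc1ccc(-c2cc(/C=C/C(=O)c3ccc(N)cc3)[nH]n2)cc1` gives -75%
compound 2 `COc1cc(-c2cc(/C=C/C(=O)c3ccc(Cl)c(Cl)c3)[nH]n2)cc(OC)c1OC` gives 2%
compound 3 `COc1ccc(C(=O)/C=C/c2cc(-c3cc(OC)c(OC)c(OC)c3)n[nH]2)cc1` gives 1%

In a functional assay on A549 cells (Homo sapiens) for cytotoxicity, read by sulforhodamine B assay, with a stated time of 48 h, tested at 100 uM (a higher number here means a weaker effect of the compound at the concentration tested, a lower number a stronger effect), compound 1 stands lowest of the three numbers, far from compound 3 and from compound 2, both beyond the scatter. Compound 4 `COc1ccc(-c2cc(/C=C/C(=O)c3ccc(N)cc3)[nH]n2)cc1OC` differs from compound 1 by methoxy in place of hydrogen on an aromatic carbon. Within the data shown here, the only measured step, a number 1 percentage points lower from compound 2 to compound 3 (within the scatter), changes the group on the carbonyl carbon and so does not bear on this change. Compounds 2 and 3 carry three methoxy groups on the pyrazole-linked ring, but they also differ from compound 1 at the carbonyl aryl, so only their values can be noted. No direct comparison exists; a weakening is expected with wide uncertainty, so compound 4 is estimated at -45%, between -85% and 15%, a step of a number 30 percentage points higher from compound 1 to compound 4 (beyond the scatter).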

Compound 4, a percentage reported as activity, at one concentration (the size of the read-out at that concentration, not a potency): -76%
For compound 4 the middle estimate is 31 percentage points above the measured one, within the range that was stated.
By their numbers in this assay, from the lowest: compounds 4 and 1 (each within the scatter of the next); then compounds 3 and 2 (each within the scatter of the next).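

Methoxy in place of hydrogen on this aromatic carbon, ortho to a methoxy group and meta to a large group, gives a number 1 percentage points lower from compound 1 to compound 4 (within the scatter) in this assay. This position therefore takes a methoxy with the strong effect kept, something compounds 2 and 3 could not show, as they also differ at the group on the carbonyl carbon. Nothing available explains this result.

On these data alone, whether a hydroxyl group, an amine or an ethoxy group at this position would read the same stays open. As far as these compounds go, with a single tested concentration, any difference in potency between compound 1 and compound 4 also stays open.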